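The compounds below may be only part of what the source reports. "The series", "measured", "known", "first", "only" and "open" are said of these compounds alone.

Measured compounds:

- Compound 1 `Cc1cc(N2CC[C@@H](C)[C@@H](N(C)c3ncnc4[nH]ccc34)C2)n2nc(SCc3cc(Cl)ccc3Cl)nc2n1`: in a toxicity assay on GES1 cells (Homo sapiens) for inhibition, read by MTT assay, with a stated time of 72 h (on this read-out lower numbers stand for stronger inhibition and higher numbers for weaker inhibition), compound 1 gives 87500 nM.
- Compound 2 `Cc1cc(N2CC[C@@H](C)[C@@H](N(C)c3ncnc4[nH]ccc34)C2)n2nc(SCc3nc4ccccc4[nH]3)nc2n1`: in this assay compound 2 gives 40200 nM.

For the measured compounds named here, compound 2 holds the lowest of the two numbers; its only neighbour is compound 1, and the one measured step, a 2.2-fold lower number from compound 1 to compound 2 (0.34 log units; beyond the scatter), separates them.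

Compound 3 `Cc1cc(N2CC[C@@H](C)[C@@H](N(C)c3ncnc4[nH]ccc34)C2)n2nc(SCc3ccc(Br)cc3)nc2n1` is not yet measured. It differs from compound 2 in one place: 4-bromophenyl in place of 1H-benzimidazol-2-yl on a saturated chain carbon bound to a sulfur. Going by the values given here, the only step that bears on this is a 2.2-fold lower number from compound 1 to compound 2 (0.34 log units; beyond the scatter), where the 1H-benzimidazol-2-yl on the saturated chain carbon bound to a sulfur replaced a halogenated phenyl and the number fell modestly. Compound 3 reverses that type of change, putting a halogenated phenyl back on the same carbon, though with bromine in a different pattern than the two chlorines of compound 1. The expectation is therefore a modest rise in this assay, back toward the number of compound 1, with a step of about a 1.9-fold higher number from compound 2 to compound 3 (0.27 log units; within the scatter) expected. For compound 3 the estimated value is 75000 nM, with a range from 35000 nM to 160000 nM.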

Compound 3, half-maximal inhibitory concentration: 55600 nM
Compound 3: the middle estimate sits 1.3-fold (0.13 log units) above what was measured; the measured number falls inside the stated range.
By their numbers in this assay, from the lowest: compounds 2, 3 and 1 (each within the scatter of the next, the first and the last beyond it).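

In this assay the change to 4-bromophenyl on a saturated chain carbon bound to a sulfur gives a 1.4-fold higher number from compound 2 to compound 3 (0.14 log units; within the scatter) on the 1H-benzimidazol-2-yl side and a 1.6-fold lower number from compound 1 to compound 3 (0.20 log units; within the scatter) on the 2,5-dichlorophenyl side, so compound 3 cannot be separated from either neighbour. For the compounds shown here, the one step beyond the scatter, a 2.2-fold lower number from compound 1 to compound 2 (0.34 log units; beyond the scatter), is now bridged by compound 3, and it no longer reads as a clean contrast between 1H-benzimidazol-2-yl and halogenated phenyl groups at this carbon: a group with a hydrogen-bond donor and acceptor and one with neither give numbers that cannot be told apart here. No supporting data bear on the cause of this result.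

The compounds shown leave open whether an aliphatic amine or a carboxylic acid in place of the aromatic group, or a longer chain in place of the single saturated carbon bound to the sulfur, would move the number beyond the scatter. They also leave open how these toxicity numbers stand against any other read-out for the same compounds.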